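Benzyl in Place of Bromophenyl: What to Expect for Compound 3

The compounds below may be only part of what the source reports. "The series", "measured", "known", "first", "only" and "open" are said of these compounds alone.

Of the compounds shown here, two have so far been measured in an assay on isolated protein for inhibition of sphingomyelin phosphodiesterase (Homo sapiens), read by fluorescence, with a stated time of 30 min; on this read-out higher numbers stand for weaker inhibition and lower numbers for stronger inhibition. Compound 1 `O=C(NO)c1cccc(OCc2ccc(-c3ccc(Cl)cc3)cc2)c1` gives 8960 nM in this assay. Compound 2 `O=C(NO)c1cccc(OCc2ccc(-c3noc(-c4ccc(Br)cc4)n3)cc2)c1` reaches only the reporting limit of this assay, giving > 100000 nM. That value is a limit and not a number, so compound 2 stands at the weak end of what this assay can report (the limit of > 100000 nM in this assay, at which 1 of the 2 values shown sits). Compound 3 `O=C(NO)c1cccc(OCc2ccc(-c3noc(Cc4ccccc4)n3)cc2)c1` has not yet been measured. It differs from compound 2 by benzyl in place of 4-bromophenyl on an aromatic carbon. No measured pair shows this change, so the size of the step can only be guessed; the two measured compounds together give no reason to expect movement beyond the scatter, and the limit for compound 2 leaves the starting point itself uncertain. Compound 3 is therefore expected to give about 90000 nM, between 25000 nM and 300000 nM. In that expectation an at least 1.1-fold lower number from compound 2 to compound 3 (0.04 log units; that floor lies within the scatter) is a step within the scatter, and this assay may well again report only a limit.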

Compound 3, half-maximal inhibitory concentration: 7830 nM
The estimate for compound 3 lay 11-fold (1.06 log units) above the measured number; the measured number lies below the stated range.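

In this assay, replacing 4-bromophenyl with benzyl on the aromatic carbon of the five-membered aromatic ring gives an at least 12-fold lower number from compound 2 to compound 3 (1.10 log units; beyond the scatter), which shows that the read-out at this position depends strongly on the group it carries. The two groups match in what is counted: each has 7 heavy atoms and one six-membered aromatic ring of carbon only, and neither has hydrogen-bond donors or acceptors, so these counts do not separate them, and the large step arises despite that match. The value of compound 2 is a limit and not a number, so the step gives only a floor for the true size of the change: the limit of > 100000 nM in this assay, at which 1 of the 3 values shown sits.

The change removes the bromine and also places a carbon between the five-membered ring and the six-membered ring, and the compounds shown cannot separate these two parts; an unsubstituted phenyl and a 4-bromobenzyl group at the same place would bear on that question. Also open, on these data alone, is how this position would respond to a longer chain such as 2-phenylethyl, or to an amine or a carboxylic acid on the six-membered ring.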